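Adding a Methyl to the Dimethylphenyl Thioether

The compounds below may be only part of what the source reports. "The series", "measured", "known", "first", "only" and "open" are said of these compounds alone.

Compound 1 `CCOC(=O)c1c(CSc2ccccc2OC)n(C)c2ccc(O)cc12`: 5100 nM
Compound 2 `CCOC(=O)c1c(CSc2c(C)cccc2C)n(C)c2ccc(O)cc12`: 1200 nM

For the measured compounds named here, of the two measured compounds, compound 2 gives the lowest number in an assay on cells for inhibition of Polyunsaturated fatty acid 5-lipoxygenase (Homo sapiens), read by HPLC, with a stated time of 15 min; on this read-out lower numbers stand for stronger inhibition and higher numbers for weaker inhibition; the only other value, that of compound 1, lies a step away: a 4.3-fold lower number from compound 1 to compound 2 (0.63 log units; beyond the scatter). Compound 3 `CCOC(=O)c1c(CSc2c(C)cc(C)cc2C)n(C)c2ccc(O)cc12` differs from compound 2 by methyl in place of hydrogen on an aromatic carbon. Going by the values given here, no measured step changes the same position, so the one step above bears only indirectly; it shows that methyl groups on this ring can lower the number. The change is therefore expected to be small, toward a lower number or none beyond the scatter: a 1.5-fold lower number from compound 2 to compound 3 (0.18 log units; within the scatter). Compound 3 is estimated at 800 nM, within 300 nM to 2500 nM.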

Compound 3, half-maximal inhibitory concentration: 230 nM
For compound 3 the middle estimate is 3.5-fold (0.54 log units) above the measured one; measured number below the stated range.
By their numbers in this assay, from the lowest: compound 3; then compound 2; then compound 1.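

In this assay, for the compounds shown here, the aromatic carbon para to a large group, which no earlier step had changed, proves to matter on its own: the added methyl gives a 5.2-fold lower number from compound 2 to compound 3 (0.72 log units; beyond the scatter) on this ring. Set against the 2-methoxyphenyl thioether, the 2,4,6-trimethylphenyl group gives a 22-fold lower number from compound 1 to compound 3 (1.35 log units; beyond the scatter) as the largest step in the series. Nothing at hand explains this gain.

From the compounds shown here alone, whether a chlorine atom, an ethyl group or a methoxy group on this same carbon would match the methyl remains open, as does whether an amine there would be tolerated.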